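From a Urea to a Carbamate on the Shared Core

The source may hold more compounds than are shown below. What is called first, only, known or untested is meant among the compounds shown, and "the series" means these compounds.

Compound 2 `COc1cc(NC(C)CCCNC(=O)N(CCO)CCO)c2ncccc2c1` sits at the top of a functional assay on HCT-116 cells (Homo sapiens); a higher number here means a weaker inhibitor, a lower number a stronger inhibitor: compound 2 gives > 100000 nM, a limit of the assay and not a number. Compound 1 `COc1cc(NC(C)CCCNC(=O)NCCCO)c2ncccc2c1` gives in this assay > 100000 nM, likewise a limit. The step that the two limits leave unreadable from compound 1 to compound 2 is accordingly unreadable, as the limit of > 100000 nM in this assay, at which 2 of the 2 values shown sit, shows. Compound 3 `CCOC(=O)NCCCC(C)Nc1cc(OC)cc2cccnc12` differs from compound 2 by ethoxy in place of bis(2-hydroxyethyl)amino on a carbonyl carbon. No measured step bears on this change, and nothing among the shown values points toward a readable gain. Compound 3 is expected to give about 100000 nM (range 30000 nM to 300000 nM), an estimated step of a number no higher from compound 2 to compound 3 (the limit leaves the size open).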

Compound 3, half-maximal inhibitory concentration: 28000 nM
Beside the measured number, compound 3's estimate is 3.6-fold (0.55 log units) above it, outside the stated range (below it).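

Compound 3 alone of the three gives a number and not a limit in this assay. On the carbonyl carbon, ethoxy in place of bis(2-hydroxyethyl)amino gives an at least 3.5-fold lower number from compound 2 to compound 3 (0.55 log units; beyond the scatter), and ethoxy in place of (3-hydroxypropyl)amino gives an at least 3.5-fold lower number from compound 1 to compound 3 (0.55 log units; beyond the scatter). Neither size is exact, and the step between the other two compounds cannot be read: the limit of > 100000 nM in this assay, at which 2 of the 3 values shown sit.

As far as these compounds go, what ethylamino on the same carbonyl carbon would give stays open, so the ethoxy oxygen cannot be separated from the loss of the hydroxyl groups. From the compounds shown here alone, whether a longer chain such as butoxy would move the number further also stays open.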